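Diallylamino in Place of 4-Chlorophenoxy on the Shared Core

The compounds below may be only part of what the source reports. "The series", "measured", "known", "first", "only" and "open" are said of these compounds alone.

- compound 1 `CC1=NN(C(=O)c2ccc(C)cc2)C(c2cc(Br)ccc2O)C1`: 21000 nM
- compound 2 `CC1=NN(C(=O)COc2ccc(Cl)cc2)C(c2cc(Br)ccc2O)C1`: 23600 nM

In a functional assay on MGC-803 cells (Homo sapiens) for cytotoxicity, read by MTT assay, with a stated time of 48 h (a lower number here means a stronger inhibitor, a higher number a weaker inhibitor), compound 2 gives 23600 nM and compound 1 gives 21000 nM, two numbers that lie within the scatter of each other. Compound 3 `C=CCN(CC=C)CC(=O)N1N=C(C)CC1c1cc(Br)ccc1O` has not yet been measured. Set against compound 2, it shows this change: diallylamino in place of 4-chlorophenoxy on a saturated chain carbon bound to a carbonyl carbon. In words, diallylamino stands in place of 4-chlorophenoxy on a saturated chain carbon bound to a carbonyl carbon. Going by the values given here, no measured pair of compounds shows this exchange, so the data offer no direct guide to its size. Only a slight lean towards a lower number is expected, with no step beyond the scatter. The estimated step is a 1.4-fold lower number from compound 2 to compound 3 (0.14 log units; within the scatter). For compound 3 the expected value is 17000 nM, with an estimated range from 6000 nM to 45000 nM.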

Compound 3, half-maximal inhibitory concentration: 10200 nM
For compound 3 the middle estimate is 1.7-fold (0.22 log units) above the measured one; measured number inside the range.
By their numbers in this assay, from the lowest: compound 3; then compounds 1 and 2 (each within the scatter of the next).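

In this assay, the saturated chain carbon bound to a carbonyl carbon proves sensitive to what it carries: diallylamino in place of 4-chlorophenoxy gives a 2.3-fold lower number from compound 2 to compound 3 (0.36 log units; beyond the scatter), whereas compounds 1 and 2 had stood within the scatter of each other. With (diallylamino)methyl in place of 4-methylphenyl on a carbonyl carbon, the result is a 2.1-fold lower number from compound 1 to compound 3 (0.31 log units; beyond the scatter), so the group without a ring gives a lower number than either group carrying a six-membered aromatic ring, although both steps are modest. Nothing measured here explains this difference.

The exchange replaces the oxygen with nitrogen, removes the aromatic ring and brings in two double bonds all at once, and the compounds shown leave open which of these changes matters. Dipropylamino, piperidine or morpholine at this place would help to separate them.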